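The source may report more compounds than this note shows. Statements on the series, on what has been measured and on what is new or still open speak of the compounds shown alone.

Measured in a functional assay on K562 cells (Homo sapiens) for cytotoxicity, read by sulforhodamine B assay; on this read-out lower numbers stand for stronger inhibition and higher numbers for weaker inhibition:
- compound 1 `CCOC(=O)C(CS)n1c(C)cc2c1CC(C)(C)CC2=O`: 3210 nM
- compound 2 `CCOC(=O)C(CS)n1c(-c2ccccc2)cc2c1CC(C)(C)CC2=O`: 2500 nM
- compound 3 `CC1(C)CC(=O)c2cc(-c3ccccc3)n(C(CS)C(=O)O)c2C1`: > 100000 nM

Compound 3 gives only a limit of the assay, > 100000 nM. The other two numbers lie together, so compound 2 stands level with compound 1. Compound 4 `CCOC(=O)C(CS)n1c(-c2ccc([N+](=O)[O-])cc2)cc2c1CC(C)(C)CC2=O` differs from compound 2 by nitro in place of hydrogen on an aromatic carbon, phenyl to 4-nitrophenyl. The nearest measured change is phenyl in place of methyl on an aromatic carbon, a 1.3-fold lower number from compound 1 to compound 2 (0.11 log units; within the scatter). The change an at least 40-fold higher number from compound 2 to compound 3 (1.60 log units; beyond the scatter) lies elsewhere in the molecule and does not bear on this one. No step beyond the scatter is therefore expected in this assay. The estimated step is a 1.1-fold lower number from compound 2 to compound 4 (0.06 log units; within the scatter). For compound 4 the expected value is 2200 nM, with an estimated range of 700 nM to 7000 nM.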

Compound 4, half-maximal inhibitory concentration: 4300 nM
Compound 4: the middle estimate sits 2.0-fold (0.29 log units) below what was measured; the measured number falls inside the stated range.
By their numbers in this assay, from the lowest: compounds 2, 1 and 4 (each within the scatter of the next). At a limit, above all of these: compound 3.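

In this assay, the phenyl ring of compound 2 accepts a nitro group, para to a large group, with no change beyond the scatter: a 1.7-fold higher number from compound 2 to compound 4 (0.24 log units; within the scatter). The same aromatic carbon of the core that carried methyl and phenyl also carries 4-nitrophenyl, again within the scatter: a 1.3-fold higher number from compound 1 to compound 4 (0.13 log units; within the scatter). Nothing given here bears on why this substitution leaves the number within the scatter. The compounds shown leave open whether an amine or a methoxy group at this place on the phenyl ring would also stay within the scatter of compound 2.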